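Compound 4 at the edge of measurable cytotoxicity

The source may hold more compounds than are shown below. What is called first, only, known or untested is meant among the compounds shown, and "the series" means these compounds.

Compound 1 `COc1cc(-c2noc(N)c2-c2ccc(Cl)cc2)cc(OC)c1OC` gives > 50000 nM as a limit
Compound 2 `COc1ccc(-c2c(-c3cc(OC)c(OC)c(OC)c3)noc2NC(C)=O)cc1` gives > 50000 nM as a limit
Compound 3 `COc1ccc(-c2c(-c3cc(OC)c(OC)c(OC)c3)noc2NC(C)=O)cc1OC` gives 46300 nM as a number

In a functional assay on SMMC-7721 cells (Homo sapiens) for cytotoxicity, read by MTT assay, with a stated time of 48 h (on this read-out lower numbers stand for stronger inhibition and higher numbers for weaker inhibition), compound 3 gives 46300 nM as the only number shown. What stands around it is the limit of > 50000 nM in this assay, at which 2 of the 3 values shown sit, and nothing firmer. The change to compound 4 `COc1cc(-c2noc(NC(C)=O)c2-c2ccc(Cl)cc2)cc(OC)c1OC` reads 4-chlorophenyl in place of 3,4-dimethoxyphenyl on an aromatic carbon and amounts to 4-chlorophenyl in place of 3,4-dimethoxyphenyl. Going by the values given here, the one measured step of an at least 1.0-fold lower number from compound 2 to compound 3 (0.03 log units; that floor lies within the scatter) touches the same aromatic group and stays within the scatter. Compound 1 also carries 4-chlorophenyl and gives > 50000 nM as a limit. No step beyond the scatter is therefore expected in this assay here. The estimated change is a 1.1-fold higher number from compound 3 to compound 4 (0.03 log units; within the scatter) and no more. For compound 4 the estimated value is 50000 nM with an expected range from 20000 nM to 100000 nM if a number is reported at all.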

Compound 4, half-maximal inhibitory concentration: > 50000 nM
Compound 4: a limit, no number; the forecaster's own chance of this, stated with the estimate: 65%; the middle value sits exactly at the limit.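

Placing 4-chlorophenyl in place of 3,4-dimethoxyphenyl on this aromatic carbon, with the acetamido group kept, gives an at least 1.0-fold higher number from compound 3 to compound 4 (0.03 log units; that floor lies within the scatter) in this assay. On these data alone, compound 4 gives > 50000 nM, which is a limit and not a number, so this change shows no gain in cytotoxicity, and the true size of the step stays unknown. The steps to compound 4 from compound 1 and from compound 2 cannot be read, and the set now rests mostly on a limit: the limit of > 50000 nM in this assay, at which 3 of the 4 values shown sit.

Still open, as far as these compounds go, is whether a carboxylic acid or a morpholine on this aromatic carbon would give a firm number in this assay.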